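Swapping a Cyclohexyloxy Group for Amino on a Sulfonamide Scaffold

This account rests on a few compounds, and the source may have more. Where it says the series, first, only, none or still open, it means among the compounds named here.

Two compounds share a common core carrying a sulfonamide and an oxan-4-yl group, and both have been measured in a physicochemical assay for lipophilicity, at pH 7.4; a lower number here means a more polar compound, a higher number a more lipophilic compound. Compound 1 `Cc1cc(C(O)(C(F)(F)F)C(F)(F)F)ccc1N(CC(C)C)S(=O)(=O)c1ccc2c(c1)C(O)CC(C1CCOCC1)O2` gives 4.37 in this assay. Compound 2 `CCc1ccc(N(CC(C)C)S(=O)(=O)c2ccc3c(c2)C(OC2CCCCC2)CC(C2CCOCC2)O3)cc1` gives 6.28 in this assay, which is the higher of the two numbers, with the value of compound 1 lying well below it, beyond the usual scatter of the measurement.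

Compound 3 `CCc1ccc(N(CC(C)C)S(=O)(=O)c2ccc3c(c2)C(N)CC(C2CCOCC2)O3)cc1` has not yet been measured in this assay. It differs from compound 2 in one place: amino in place of cyclohexyloxy on a saturated ring carbon. A large group of carbon and oxygen atoms leaves, and a single nitrogen atom that carries a hydrogen-bond donor enters on the same saturated ring carbon.

Given that compound 2 sits at 6.28 in this assay, a substantial drop toward the polar end is expected, estimated at a number 3.48 log units lower from compound 2 to compound 3 (beyond the scatter). Compound 3 is therefore expected to give about 2.8 in this assay, most likely between 1.8 and 3.8.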

Compound 3, distribution coefficient: 3.08
Compound 3: middle estimate off by 0.28 log units, on the low side; the measured number falls inside the stated range.
By their numbers in this assay, from the lowest: compound 3; then compound 1; then compound 2.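

Compounds 1 and 2 differ in several places, so they could not show what any single group contributes to the number in this assay. The new pair isolates one place, the saturated ring carbon two ring bonds from the ring atom that bears the oxan-4-yl group, and the change there gives a number 3.20 log units lower from compound 2 to compound 3 (beyond the scatter) while the rest of the molecule stays the same; a single substituent on this carbon can therefore shift the read-out by a large amount, with cyclohexyloxy and its 7 heavy atoms giving way to amino with 1 heavy atom and 1 hydrogen-bond donor. No measurement shown here accounts for the size of this step.

This one swap removes a carbon ring, replaces oxygen with nitrogen and adds a hydrogen-bond donor all at once, so the compounds shown leave open how much of the step belongs to each of these changes. A cyclohexylamino group or a methoxy group on the same saturated ring carbon would begin to pull them apart, the first keeping the carbon ring with nitrogen in place of oxygen, the second keeping the oxygen without the carbon ring.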